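This account rests on a few compounds, and the source may have more. Where it says the series, first, only, none or still open, it means among the compounds named here.

Measured so far:
Compound 1, `CCc1cc2ccccc2nc1-c1cn(-c2ccc(F)cc2)nn1`: > 100 ug/mL
Compound 2, `CCCCCc1cc2ccccc2nc1-c1cn(CCC(F)(F)C(F)(F)C(F)(F)C(F)(F)C(F)(F)C(F)(F)C(F)(F)C(F)(F)F)nn1`: > 100 ug/mL

In a functional assay on HeLa cells (Homo sapiens) for cytotoxicity, read by MTT assay, with a stated time of 24 h (on this read-out higher numbers stand for weaker inhibition and lower numbers for stronger inhibition), compound 1 gives > 100 ug/mL, which is a limit of the assay rather than a number. Compound 2 gives > 100 ug/mL, also a limit. Among the measured compounds shown here, both values sit at the limit of > 100 ug/mL in this assay, at which 2 of the 2 values shown sit, so no step between measured compounds can be sized. Compound 3, `CCCc1cc2ccccc2nc1-c1cn(-c2ccc(F)cc2)nn1`, differs from compound 1 by methyl in place of hydrogen on a saturated chain carbon, two bonds along the chain from an aromatic carbon. Given that compound 1 sits at the limit of > 100 ug/mL in this assay, at which 2 of the 2 values shown sit, compound 3 is expected to stay near that limit, with an expected step of a number no higher from compound 1 to compound 3 (the limit leaves the size open) that means no change beyond the scatter. The estimate for compound 3 is 100 ug/mL, between 50 ug/mL and 200 ug/mL.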

Compound 3, half-maximal inhibitory concentration: > 100 ug/mL
Compound 3 gave a limit, no number; the forecaster's own chance of this, stated with the estimate: 85%; the middle value lies on the limit itself.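

No step can be read from compound 1 to compound 3, since both results are limits rather than numbers: the limit of > 100 ug/mL in this assay, at which 3 of the 3 values shown sit.

In this assay the compounds shown leave open whether the methyl in place of hydrogen changes anything, and what real value lies behind each limit.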